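The source may report more compounds than this note shows. Statements on the series, on what has been measured and on what is new or still open speak of the compounds shown alone.

Among the compounds with values here, compound 1 `Oc1cccc2c1CCCC2c1c[nH]cn1` is the one compound in this set for which a full number is available: in an assay on isolated protein for binding affinity to Alpha-1D adrenergic receptor (Rattus norvegicus), read by radioligand binding (a lower number here means a stronger inhibitor, a higher number a weaker inhibitor), compound 1 gives 30.9 nM. The other entry belongs to compound 2 `CCS(=O)(=O)Nc1cccc2c1CCCC2CN`, and for compound 2 the result in this assay is reported only as a limit, < 10000 nM, so it carries no number that could be set against compound 1; this is the limit of < 10000 nM in this assay, at which 1 of the 2 values shown sits. Within the data shown here, no two measured compounds here differ in only one place, so no measured step exists.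

The unmeasured compound is compound 3 `CC(C)S(=O)(=O)Nc1cccc2c1CCCC2c1c[nH]cn1`. It differs from compound 1 by (isopropylsulfonyl)amino in place of hydroxy on an aromatic carbon, and the change sits on an aromatic carbon of a six-membered aromatic ring of carbon only, part of a fused system of two rings. Nothing measured in this assay tells how a change of this kind moves the inhibition constant, so the expectation rests on compound 1 alone. His expectation is a step from compound 1 to compound 3 of a 6.5-fold higher number from compound 1 to compound 3 (0.81 log units; beyond the scatter), toward weaker binding and beyond the usual scatter. Compound 3 is therefore estimated at 200 nM, within a range from 40 nM to 1500 nM.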

Compound 3, inhibition constant: 2040 nM
For compound 3 the middle estimate is 10-fold (1.01 log units) below the measured one; the measured number lies above the stated range.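

In this assay, within the data shown here, putting (isopropylsulfonyl)amino in place of hydroxy on this aromatic carbon gives a 66-fold higher number from compound 1 to compound 3 (1.82 log units; beyond the scatter) and so provides the first measured step at this place. The change costs much of the binding seen with hydroxy, yet in this assay compound 3 still gives a full number, 2040 nM and this shows that the shared core can carry the much larger group at this place and remain measurable. Nothing shown accounts for the size of this step.

As far as these compounds go, a single step cannot separate what is lost with the hydroxy from what the incoming group adds, so it remains open whether a simple amine or a methoxy group on the same aromatic carbon would stay closer to compound 1 or to compound 3. From the compounds shown here alone, it is also open whether a methyl or a longer alkyl chain on the sulfonyl group, in place of isopropyl, would move the inhibition constant in either direction.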